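Swapping the sulfur-linked triazole for an ethylpiperazine

The compounds below may be only part of what the source reports. "The series", "measured", "known", "first", "only" and "open" are said of these compounds alone.

Compounds measured so far in a functional assay on HT-29 cells (Homo sapiens) for cytotoxicity, read by MTT assay, with a stated time of 24 h; on this read-out higher numbers stand for weaker inhibition and lower numbers for stronger inhibition:
Compound 1, `Cn1c(-c2ccc(NC(=O)CSc3nc4cc(Cl)ccc4o3)cc2)nc(-c2ccccc2)c1-c1ccccc1`, gives 20.6 ug/mL.
Compound 2, `Cn1cnnc1SCC(=O)Nc1ccc(-c2nc(-c3ccccc3)c(-c3ccccc3)n2C)cc1`, gives 10.7 ug/mL.
Compound 3, `Cn1c(-c2ccc(NC(=O)CSC3=NCCS3)cc2)nc(-c2ccccc2)c1-c1ccccc1`, gives 21 ug/mL.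

Compound 2 has the lowest number of the group, but the steps to its neighbours, a 1.9-fold lower number from compound 1 to compound 2 (0.28 log units; within the scatter) and a 2.0-fold higher number from compound 2 to compound 3 (0.29 log units; within the scatter), both lie within the scatter, so the values do not separate these compounds. The step of a 1.0-fold higher number from compound 1 to compound 3 (0.01 log units; within the scatter) is likewise within the scatter. Every change tested so far keeps the sulfur and varies the ring on it.

Compound 4, `CCN1CCN(CC(=O)Nc2ccc(-c3nc(-c4ccccc4)c(-c4ccccc4)n3C)cc2)CC1`, departs from that pattern: 4-ethylpiperazin-1-yl in place of (4-methyl-4H-1,2,4-triazol-3-yl)sulfanyl on a saturated chain carbon bound to a carbonyl carbon. Among the measured compounds shown here, none of the measured steps covers a change of this kind; they only show that altering the group on the sulfur left the number where it was. That gives no basis to expect a shift beyond the scatter, while leaving the outcome quite uncertain. Compound 4 is therefore expected to give 15 ug/mL in this assay, within the range 5 ug/mL to 45 ug/mL, which corresponds to an expected step of a 1.4-fold higher number from compound 2 to compound 4 (0.15 log units; within the scatter).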

Compound 4, half-maximal inhibitory concentration: 75 ug/mL
Compound 4: middle estimate off by 5.0-fold (0.70 log units), on the low side; the measured number lies above the stated range.
By their numbers in this assay, from the lowest: compounds 2, 1 and 3 (each within the scatter of the next); then compound 4.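

In this assay the saturated chain carbon bound to a carbonyl carbon turns out to be a place where a change can move the number: 4-ethylpiperazin-1-yl in place of (4-methyl-4H-1,2,4-triazol-3-yl)sulfanyl comes with a 7.0-fold higher number from compound 2 to compound 4 (0.85 log units; beyond the scatter) whereas changing only the ring on the sulfur had stayed within the scatter. The other two sulfur-linked compounds point the same way, with a 3.6-fold higher number from compound 1 to compound 4 (0.56 log units; beyond the scatter) and a 3.6-fold higher number from compound 3 to compound 4 (0.55 log units; beyond the scatter) so all three inhibit more strongly than compound 4. Nothing measured here explains the shift.

This swap removes the sulfur and replaces the ring together, so the compounds shown leave open which of the two matters. A dimethylamino group or a morpholine ring on the same carbon, or a piperazine ring held on the sulfur, would begin to separate them.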